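Changing the Aryl on the Triazole Toward Compound 4

A few compounds are considered here, and "the series" means these few. Any claim that something is new, unique, unknown or untested is made for them only; others in the source may bear on it.

Measured so far in an ADME assay on L02 cells (Homo sapiens) for antiproliferative activity, read by MTT assay, with a stated time of 48 h; on this read-out lower numbers stand for stronger inhibition and higher numbers for weaker inhibition:
Compound 1, `N#CC1=C(N)Oc2c(N)cc3nc4ccccc4nc3c2C12C(=O)N(Cc1cnnn1-c1ccccc1Br)c1ccccc12`, gives 29200 nM.
Compound 2, `COc1ccc(-n2nncc2CN2C(=O)C3(C(C#N)=C(N)Oc4c(N)cc5nc6ccccc6nc5c43)c3ccccc32)cc1`, gives only a limit, > 50000 nM.
Compound 3, `N#CC1=C(N)Oc2c(N)cc3nc4ccccc4nc3c2C12C(=O)N(Cc1cnnn1-c1ccc([N+](=O)[O-])cc1)c1ccccc12`, also gives only a limit, > 50000 nM.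

Compound 3 thus stands at the limit of this assay, where compound 2 sits as well (the limit of > 50000 nM in this assay, at which 2 of the 3 values shown sit), so only compound 1 yields a number. The steps that lead there are small at their floor: an at least 1.7-fold higher number from compound 1 to compound 2 (0.23 log units; that floor lies within the scatter) and an at least 1.7-fold higher number from compound 1 to compound 3 (0.23 log units; that floor lies within the scatter). Between the two limits, a step that the two limits leave unreadable from compound 2 to compound 3.

Compound 4 is `N#CC1=C(N)Oc2c(N)cc3nc4ccccc4nc3c2C12C(=O)N(Cc1cnnn1-c1c(F)cccc1F)c1ccccc12`. The change from compound 3 is 2,6-difluorophenyl in place of 4-nitrophenyl on an aromatic nitrogen. For the measured compounds named here, no measured step makes this exact exchange. The nearest evidence is the reverse sense of an at least 1.7-fold higher number from compound 1 to compound 3 (0.23 log units; that floor lies within the scatter), where a halogen-bearing phenyl on that ring nitrogen, as in compound 1, gave a readable number while the 4-nitrophenyl did not; the floor of that step, however, lies within the scatter. A return toward the region of compound 1 is therefore possible but not assured, and compound 4 may equally remain at the limit.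

Compound 4 is expected at about 40000 nM, within 15000 nM to 120000 nM, which amounts to an expected step of an at least 1.2-fold lower number from compound 3 to compound 4 (0.09 log units; that floor lies within the scatter).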

Compound 4, half-maximal inhibitory concentration: > 50000 nM
Compound 4 gave a limit, no number; the forecaster's own chance of this, stated with the estimate: 45%; middle value at least 1.2-fold (0.09 log units) from the limit.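

In this assay compound 4 gives a limit and not a number, so a halogen-bearing phenyl on this ring nitrogen does not by itself yield a readable value, and compound 1, with its 2-bromophenyl, remains the only compound shown that does. The one readable new step is an at least 1.7-fold higher number from compound 1 to compound 4 (0.23 log units; that floor lies within the scatter), so even this exchange, from one halogen-bearing phenyl to another, is not shown to move the value beyond ordinary variation. The steps among compound 2, compound 3 and compound 4 cannot be read, and with 2,6-difluorophenyl added, this position now offers very little numerical contrast: the limit of > 50000 nM in this assay, at which 3 of the 4 values shown sit.

From the compounds shown here alone, whether the number for compound 1 belongs to the bromine itself or to where it sits on the phenyl ring stays open, and the limits also leave unknown how far compound 2, compound 3 and compound 4 lie from one another. Going by these compounds, how a plain phenyl, a chlorophenyl or an aminophenyl on the same ring nitrogen would read also remains open, and any of these could help separate the role of the halogen from that of the phenyl ring.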